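Compound 2 to compound 4: losing the nitro group

The source may report more compounds than this note shows. Statements on the series, on what has been measured and on what is new or still open speak of the compounds shown alone.

In a functional assay on PANC-1 cells (Homo sapiens) for antiproliferative activity, read by fluorescence and resazurin assay, with a stated time of 48 h (on this read-out lower numbers stand for stronger inhibition and higher numbers for weaker inhibition), compound 2 `CCOc1ccc2nc(Cl)c(/C=N/NC(=O)c3cc4cc([N+](=O)[O-])ccc4oc3=O)cc2c1` gives 10500 nM. That lies within the scatter of compound 3 `O=C(N/N=C/c1cccnc1)c1cc2ccccc2oc1=O` at 15300 nM, while compound 1 `O=C(N/N=C/c1cccnc1)c1cc2ccc(O)cc2oc1=O` gives a lower 2530 nM, a gap beyond the scatter. Compound 4 `CCOc1ccc2nc(Cl)c(/C=N/NC(=O)c3cc4ccccc4oc3=O)cc2c1` differs from compound 2 by hydrogen in place of nitro on an aromatic carbon. Going by the values given here, no measured step covers this exact change. Among the compounds with values here, the only measured step, a 6.0-fold higher number from compound 1 to compound 3 (0.78 log units; beyond the scatter), is modest and beyond the scatter, and it also puts hydrogen on an aromatic carbon, but in place of hydroxy, so it is weak guidance. A small rise in this assay is therefore expected, not clearly beyond the scatter. The expected step is a 1.3-fold higher number from compound 2 to compound 4 (0.12 log units; within the scatter). Compound 4 is estimated at 14000 nM, with an expected range of 5000 nM to 35000 nM.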

Compound 4, half-maximal inhibitory concentration: 29900 nM
Estimate against measurement, compound 4: 2.1-fold (0.33 log units) below, within the range that was stated.
By their numbers in this assay, from the lowest: compound 1; then compounds 2, 3 and 4 (each within the scatter of the next, the first and the last beyond it).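

In this assay the nitro group proves not to be a silent substituent: the step is a 2.8-fold higher number from compound 2 to compound 4 (0.45 log units; beyond the scatter), so hydrogen on this aromatic carbon gives weaker inhibition. Until now only hydroxy had been exchanged for hydrogen, in the pair compound 1 and compound 3, and nitro now gives a change in the same direction on the core of compound 2. No measured evidence bears on the reason for this step. From the compounds shown here alone, whether an amine or a methoxy group on this carbon would retain the lower number remains open.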